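A few compounds are considered here, and "the series" means these few. Any claim that something is new, unique, unknown or untested is made for them only; others in the source may bear on it.

Measured so far in this study:
compound 1, `N#CC1CN1C(=O)Nc1ccc(S(N)(=O)=O)cc1`: > 15000 nM, a limit of the assay rather than a number
compound 2, `CNC(=O)N1CC1C#N`: 17000 nM
compound 3, `N#CC1CN1C(=O)Nc1ccccc1`: 2600 nM

In a functional assay on MCF7 cells (Homo sapiens) for inhibition (a higher number here means a weaker inhibitor, a lower number a stronger inhibitor), compound 2 gives 17000 nM, the higher of the two numbers recorded. Its nearest neighbour is compound 3, which in this assay gives 2600 nM, a gap that lies beyond the scatter. Going by the values given here, the only step measured between two compounds is an at least 5.7-fold lower number from compound 1 to compound 3 (0.76 log units; beyond the scatter), a change on the aromatic ring.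

Compound 4, `CCNC(=O)N1CC1C#N`, differs from compound 2 by methyl in place of hydrogen on a saturated chain carbon bound to an amide-type nitrogen. Among the compounds with values here, no measured step touches the saturated chain carbon bound to the amide-type nitrogen, and the change on the aromatic carbon says nothing about a methyl group on the chain. Without such a precedent, the expected step is a 1.1-fold lower number from compound 2 to compound 4 (0.05 log units; within the scatter), not beyond the scatter. Compound 4 is accordingly estimated at 15000 nM in this assay, with a range from 6000 nM to 40000 nM.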

Compound 4, half-maximal inhibitory concentration: 20000 nM
Beside the measured number, compound 4's estimate is 1.3-fold (0.12 log units) below it, and the stated range covers the measured number.
By their numbers in this assay, from the lowest: compound 3; then compounds 2 and 4 (each within the scatter of the next).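

Going by these compounds alone, the step from methylamino to ethylamino, a 1.2-fold higher number from compound 2 to compound 4 (0.07 log units; within the scatter), in this assay, is the first measured at a saturated chain carbon bound to an amide-type nitrogen. It shows that one added methyl at this place does not separate the two compounds beyond the scatter, something the earlier step on the aromatic carbon could not show. Nothing measured here gives a reason for this result.

From the compounds shown here alone, whether a longer chain such as propyl, or an amine or a carboxylic acid on this saturated chain carbon, would move the number beyond the scatter remains open. Also open, going by these compounds, is whether a single step of this kind holds for any shared core other than that of compound 2.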